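Hydroxy in place of fluoro: cytotoxicity notes

A few compounds are considered here, and "the series" means these few. Any claim that something is new, unique, unknown or untested is made for them only; others in the source may bear on it.

Compound 1 `Cc1ccc(S(=O)(=O)N[C@@H](CC(=O)NC(C)(C)C)C(=O)NCCNC(=O)c2ccccc2F)cc1` was run in an ADME assay on Karpas-1106P cells (Homo sapiens) for cytotoxicity; a higher number here means that more compound is needed for the effect, a lower number that less compound is needed. In this assay compound 1 gives only a limit, > 11100 nM. Compound 2 `Cc1ccc(S(=O)(=O)N[C@@H](CC(=O)NC(C)(C)C)C(=O)NCCNC(=O)c2cccc(C#N)c2)cc1` likewise gives only a limit, > 11100 nM. Compound 3 `Cc1ccc(S(=O)(=O)N[C@@H](CC(=O)NC(C)(C)C)C(=O)NCCNC(=O)NCc2ccccc2)cc1` also gives only a limit, > 11100 nM. The steps among these three are accordingly not readable: a step that the two limits leave unreadable from compound 1 to compound 2, a step that the two limits leave unreadable from compound 1 to compound 3 and a step that the two limits leave unreadable from compound 2 to compound 3. All three values sit at the limit of > 11100 nM in this assay, at which 3 of the 3 values shown sit, so compound 1 stands with the other two at the limit and cannot be placed against them.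

Compound 4 `Cc1ccc(S(=O)(=O)N[C@@H](CC(=O)NC(C)(C)C)C(=O)NCCNC(=O)c2ccccc2O)cc1` differs from compound 1 in one place: hydroxy in place of fluoro on an aromatic carbon. Among the measured compounds shown here, none of the measured steps bears on this change directly; each of them replaces the whole 2-fluorophenyl on the carbonyl carbon, and each is unreadable. Replacing 2-fluorophenyl by 3-cyanophenyl or by benzylamino left the reading at the limit, so a change confined to hydroxy in place of fluoro on the same ring is expected to leave the reading at the limit as well, with no step beyond the scatter. The step from compound 1 to compound 4 is estimated as a step that the limit leaves unreadable from compound 1 to compound 4. Compound 4 is therefore expected at 15000 nM, between 7000 nM and 40000 nM, most probably reported as a limit once more.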

Compound 4, half-maximal effective concentration: > 11100 nM
Compound 4 gave a limit, no number (the forecaster's own chance of this, stated with the estimate: 85%); the middle value lies beyond the limit too.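

In this assay compound 4 gives > 11100 nM, again a limit and not a number. No step between compound 4 and compound 1, compound 2 or compound 3 can be read: the limit of > 11100 nM in this assay, at which 4 of the 4 values shown sit.

The compounds shown leave open what change to the shared core, if any, would give a measured number rather than a limit.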